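Solubility of compound 4 after one side-group swap

The compounds below may be only part of what the source reports. "The series", "measured", "known", "first", "only" and "open" are said of these compounds alone.

Measured in a physicochemical assay for solubility; on this read-out lower numbers stand for lower solubility and higher numbers for higher solubility:
- Compound 1 `O=C(O)c1ccc(C(=O)/C(=C\c2ccc(F)c([N+](=O)[O-])c2)S(=O)(=O)Cc2ccc(Br)cc2)cc1` gives < 1000 ug/mL
- Compound 2 `O=C(O)c1ccc(C(=O)/C(=C\c2cc([N+](=O)[O-])ccc2F)SCc2ccc(Br)cc2)cc1` gives < 1000 ug/mL
- Compound 3 `O=C(O)c1ccc(C(=O)/C(=C\c2ccc(Br)c([N+](=O)[O-])c2)SCc2ccc(Cl)cc2)cc1` gives < 1000 ug/mL

In this assay compound 1 gives < 1000 ug/mL, which is a limit of the assay and not a number. Across the measured compounds the picture is the limit of < 1000 ug/mL in this assay, at which 3 of the 3 values shown sit. Compound 4 `Cc1ccc(CS/C(=C/c2ccc(F)c([N+](=O)[O-])c2)C(=O)c2ccc(C(=O)O)cc2)cc1` has not yet been measured. It differs from compound 1 in one place (4-methylbenzyl)sulfanyl in place of (4-bromobenzyl)sulfonyl on a double-bonded chain carbon bound to a carbonyl carbon and a double-bonded chain carbon. Among the measured compounds shown here, no measured pair shows the size of such a step, so in this assay no step beyond the scatter is expected, in either direction. The estimated step is a step that the limit leaves unreadable from compound 1 to compound 4. For compound 4 the expected value is 300 ug/mL, with an estimated range from 30 ug/mL to 1000 ug/mL.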

Compound 4, solubility: < 1000 ug/mL
Compound 4 was reported as a limit; the forecaster's own chance of this, stated with the estimate: 90%; the middle value is on the limit's open side.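

Compound 1 and compound 4 are both reported as limits and not numbers, so no step between them can be read, and the picture stays as it was: the limit of < 1000 ug/mL in this assay, at which 4 of the 4 values shown sit.

The compounds shown leave open what actual number any of them would give in this assay, and whether (4-methylbenzyl)sulfanyl in place of (4-bromobenzyl)sulfonyl shifts that number at all.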